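The compounds below may be only part of what the source reports. "The series", "measured", "known", "first", "only" and "open" are said of these compounds alone.

Compound 1 `O=S(=O)(Nc1ccc2oc(-c3ccccc3)nc2c1)c1ccc(Cl)c(Cl)c1`: in an assay on cells for inhibition of HSP60/HSP10 (Homo sapiens), with a stated time of 60 min (a higher number here means a weaker inhibitor, a lower number a stronger inhibitor), compound 1 reaches only the limit > 100000 nM.
Compound 2 `O=S(=O)(Nc1ccc(-c2nc3ccccc3o2)cc1)c1cccc(C(F)(F)F)c1`: compound 2 gives 57000 nM.
Compound 3 `COc1cccc(S(=O)(=O)Nc2ccc(-c3nc4ccccc4o3)cc2)c1`: compound 3 gives 80000 nM.

Among these three, compound 1 stands at the limit of this assay, (the limit of > 100000 nM in this assay, at which 1 of the 3 values shown sits), so it has no number of its own, while compound 2 and compound 3 carry numbers. Compound 4 `O=S(=O)(Nc1ccc2oc(-c3ccccc3)nc2c1)c1ccc(Cl)cc1` differs from compound 1 by hydrogen in place of chloro on an aromatic carbon. Going by the values given here, the one measured step that bears on a change of this kind is a 1.4-fold higher number from compound 2 to compound 3 (0.15 log units; within the scatter), also a swap of a single group on an aromatic carbon of a six-membered aromatic ring of carbon only, and it stayed within the scatter. Nothing measured here shows that removing a chloro group shifts this assay beyond the scatter, so no step beyond the scatter is expected from compound 1 to compound 4, and compound 4 will most likely also sit at or near the limit. Compound 4 is therefore estimated at 150000 nM, within 50000 nM to 500000 nM, meaning an expected step that the limit leaves unreadable from compound 1 to compound 4.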

Compound 4, half-maximal inhibitory concentration: > 100000 nM
Compound 4: a limit, no number (the forecaster's own chance of this, stated with the estimate: 70%); the middle value is on the limit's open side.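

Going by these compounds alone, compound 1 and compound 4 both give only a limit in this assay and not a number, so no step between them can be read: the limit of > 100000 nM in this assay, at which 2 of the 4 values shown sit. The compounds shown leave open whether going from 3,4-dichlorophenyl to 4-chlorophenyl changes the inhibition at all.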